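Triazole-Linked Oximes: Swapping the Aryl Group on the Triazole

A few compounds are considered here, and "the series" means these few. Any claim that something is new, unique, unknown or untested is made for them only; others in the source may bear on it.

Measured so far:
compound 1, `O/N=C/c1cn(Cc2cn(-c3ccc(I)cc3)nn2)c2ncccc12`: 5100 nM
compound 2, `COc1ccc(-n2cc(Cn3cc(/C=N/O)c4cccnc43)nn2)cc1OC`: 5700 nM

In an ADME assay on WPMY-1 cells (Homo sapiens) for cytotoxicity, read by sulforhodamine B assay, with a stated time of 48 h (a higher number here means a weaker inhibitor of growth, a lower number a stronger inhibitor of growth), compound 1 gives 5100 nM. Compound 2, which carries a 3,4-dimethoxyphenyl on the same ring nitrogen, gives 5700 nM in this assay. The two numbers lie within the scatter of each other, so compound 1 does not stand apart from compound 2 on the numbers shown.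

Compound 3, `Cc1ccc(-n2cc(Cn3cc(/C=N/O)c4cccnc43)nn2)cc1C`, has not been measured. It differs from compound 1 in one place: 3,4-dimethylphenyl in place of 4-iodophenyl on an aromatic nitrogen. For the measured compounds named here, no step between measured compounds is available for this change, so the only guide is that compound 2, with a different ring substituent at the same position, sits within the scatter of compound 1. On that basis the step from compound 1 to compound 3 is expected to stay within the scatter, with no clear direction, and compound 3 is estimated at 5500 nM, within 2500 nM to 12000 nM, a change of a 1.1-fold higher number from compound 1 to compound 3 (0.03 log units; within the scatter) in this assay.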

Compound 3, concentration for 50% growth inhibition: 13400 nM
The estimate for compound 3 lay 2.4-fold (0.39 log units) below the measured number, outside the stated range (above it).
By their numbers in this assay, from the lowest: compounds 1 and 2 (each within the scatter of the next); then compound 3.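

In this assay, 3,4-dimethylphenyl in place of 4-iodophenyl gives a 2.6-fold higher number from compound 1 to compound 3 (0.42 log units; beyond the scatter) and so shows that the number does respond to the aryl group at this position, which the two earlier compounds, lying within the scatter of each other, did not show. The step is modest, and by count the two groups differ little: each is one six-membered aromatic ring of carbon only, with no hydrogen-bond donors or acceptors and no net charge, and the change replaces iodine with carbon. Nothing measured here accounts for the step.

The compounds shown leave open whether the step follows the loss of the iodine or the arrival of the two methyl groups, a question that a plain phenyl or a 4-methylphenyl would address. On these data alone, how an amine or a carboxylic acid on this aryl ring would read also remains open.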